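A few compounds are considered here, and "the series" means these few. Any claim that something is new, unique, unknown or untested is made for them only; others in the source may bear on it.

Compound 1, `Cn1c(C(F)(F)F)ccc(NCc2cc3cc(Cl)ccc3[nH]c2=O)c1=O`: 67%
Compound 2, `COc1cccc(NCc2cc3cc(Cl)ccc3[nH]c2=O)c1`: 19%
Compound 3, `CCn1cccc(NCc2cc3cc(Cl)ccc3[nH]c2=O)c1=O`: 7%

All three compounds share one core and were tested in an ADME assay on microsomes from liver (Mus musculus) for metabolic stability, with a stated time of 30 min; a lower number here means that less of the compound is left, a higher number that more of the compound is left. Compound 1 gives 67%, the highest of the three numbers. Compound 2 gives 19%, and compound 3 gives 7%; both gaps to compound 1 lie beyond the usual scatter of such measurements, so compound 1 clearly stands above the other two.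

Compound 4, `Cn1c(C#N)ccc(NCc2cc3cc(Cl)ccc3[nH]c2=O)c1=O`, has not yet been measured. It differs from compound 1 in one place: cyano in place of trifluoromethyl on an aromatic carbon. Among the compounds with values here, no two measured compounds differ from each other by a single change, so no measured step shows how this kind of swap moves the read-out. In this assay a modest downward step from compound 1 is expected, though a result within the scatter cannot be ruled out. Compound 4 is therefore estimated at 50%, with a range from 25% to 75%. The expected step is a number 17 percentage points lower from compound 1 to compound 4 (beyond the scatter).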

Compound 4, percent of the compound remaining in the Mus musculus assay: 73%
Beside the measured number, compound 4's estimate is 23 percentage points below it; measured number inside the range.
By their numbers in the Mus musculus assay, from the lowest: compound 3; then compound 2; then compounds 1 and 4 (each within the scatter of the next).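

Within the data shown here, for the first time, one change can be read on its own: with cyano in place of trifluoromethyl on this aromatic carbon, the Mus musculus assay shows a number 6 percentage points higher from compound 1 to compound 4 (within the scatter), so trifluoromethyl is not needed here to hold this read-out. In a physicochemical assay for solubility (on this read-out higher numbers stand for higher solubility and lower numbers for lower solubility), compound 1 gives < 100 nM, which is a limit of the assay and not a number: the limit of < 100 nM in the physicochemical assay, at which 1 of the 2 values shown sits.
In the physicochemical assay compound 4 gives 295 nM, and the step there reads an at least 2.9-fold higher number from compound 1 to compound 4 (0.46 log units; beyond the scatter), so the same swap that leaves stability within the scatter comes with a clear gain on this second read-out.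

Still open, from the compounds shown here alone, is how a chlorine atom, an amine or a carboxylic acid would read on this same carbon. Compound 3 differs from compounds 1 and 4 in more than one place, so what any group here adds over a plain hydrogen also stays unread.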